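The compounds below may be only part of what the source reports. "The series", "measured", "known", "first", "only" and "open" are said of these compounds alone.

Measured compounds in an assay on CHO cells for antagonist activity at transient receptor potential cation channel subfamily V member 1 (Homo sapiens), read by FLIPR; on this read-out higher numbers stand for weaker inhibition and lower numbers for stronger inhibition:
- compound 1, `Cc1cc(-c2nc(C(F)(F)F)ccc2CNC(=O)C(C)c2ccc(NS(C)(=O)=O)c(F)c2)ccc1F`: 0.4 nM
- compound 2, `CC(C(=O)NCc1ccc(C(F)(F)F)nc1-c1ccc2c(c1)OCCO2)c1ccc(NS(C)(=O)=O)c(F)c1`: 5 nM

Compound 2 gives the highest of the two numbers in this assay; its nearest neighbour is compound 1, and the step of a 13-fold higher number from compound 1 to compound 2 (1.10 log units; beyond the scatter) separates them, beyond the scatter. That step is the single one in the set and it changes the same aromatic carbon that the next step addresses.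

Compound 3, `CC(C(=O)NCc1ccc(C(F)(F)F)nc1/C=C/c1ccccc1)c1ccc(NS(C)(=O)=O)c(F)c1`, is the next compound to be measured in this assay. Relative to compound 2 the change is 2-phenylethenyl in place of 2,3-dihydro-1,4-benzodioxin-6-yl on an aromatic carbon. The group that enters carries no hydrogen-bond acceptor, while the group that leaves carries two; the group in compound 1 at this position also carries none and gives the lower number. Among the compounds with values here, no measured step covers the entering 2-phenylethenyl group, so the direction rests only on the single step from compound 1 to compound 2 and on the shared core. Compound 3 is therefore expected to land near compound 2, the step of a 1.2-fold higher number from compound 2 to compound 3 (0.08 log units; within the scatter) being estimated as within or close to the scatter. Compound 3 is estimated at 6 nM, range 1.5 nM to 30 nM.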

Compound 3, inhibition constant: 2.2 nM
Estimate against measurement, compound 3: 2.7-fold (0.44 log units) above, within the range that was stated.
By their numbers in this assay, from the lowest: compound 1; then compound 3; then compound 2.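

In this assay, the step of a 2.3-fold lower number from compound 2 to compound 3 (0.36 log units; beyond the scatter) shows that this place, next to the ring nitrogen, accepts 2-phenylethenyl, a group with a double bond outside aromatic rings, and that it reads better than 2,3-dihydro-1,4-benzodioxin-6-yl. Both groups without hydrogen-bond acceptors now give lower numbers than the group that carries them, but the step of a 5.5-fold higher number from compound 1 to compound 3 (0.74 log units; beyond the scatter) separates those two acceptor-free groups, so the acceptor count alone does not set the order and 4-fluoro-3-methylphenyl remains the best group shown here. Within the data shown here, with only three groups compared at one position, these steps describe a ranking and no more, and nothing available bears on what lies behind them.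

The compounds shown leave open whether the double bond itself contributes, as a saturated 2-phenylethyl chain would test directly, and how a non-aromatic group such as a morpholine or a simple amine would read at this place. They also leave open whether the order of these groups holds on any other core, since all three compounds share a single one.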